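Methyl to Methoxy Beside an Isopropoxy Group: Still a Limit

The source may hold more compounds than are shown below. What is called first, only, known or untested is meant among the compounds shown, and "the series" means these compounds.

Compound 1 `Cc1cc(CCC(=O)O)ccc1-c1noc(-c2ccc(OC(C)C)c(F)c2)n1` gives > 10000 nM in a functional assay on CHO cells with sphingosine 1-phosphate receptor 4 (Homo sapiens) as the target, read by GTPgammaS binding; a lower number here means that less compound is needed, a higher number that more compound is needed for the effect. Compound 2 `Cc1cc(-c2nc(-c3ccc(CCC(=O)O)cc3C)no2)ccc1OC(C)C` gives > 10000 nM in this assay.

Both of these values are limits of the assay, not numbers. The step that the two limits leave unreadable from compound 1 to compound 2 therefore cannot be read. Compound 2 stands at the limit of > 10000 nM in this assay, at which 2 of the 2 values shown sit, so nothing places it against compound 1. Compound 3 `COc1cc(-c2nc(-c3ccc(CCC(=O)O)cc3C)no2)ccc1OC(C)C` differs from compound 2 by methoxy in place of methyl on an aromatic carbon. For the measured compounds named here, no measured step bears on this change, since the only step available is unreadable. Compound 3 is therefore expected to remain at the limit as well, estimated at 20000 nM (range 5000 nM to 100000 nM), which means an expected step that the limit leaves unreadable from compound 2 to compound 3.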

Compound 3, half-maximal effective concentration: > 10000 nM
Compound 3: only a limit was reported (the forecaster's own chance of this, stated with the estimate: 85%); the middle value does not contradict the limit.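

Compound 3 gives > 10000 nM as a limit of the assay and not a number, so its steps from compound 1 and compound 2 cannot be read. The compounds shown leave open whether fluoro, methyl or methoxy at this place changes the result in this assay at all.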